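This account rests on a few compounds, and the source may have more. Where it says the series, first, only, none or still open, it means among the compounds named here.

Measured compounds: compound 1, `CS(=O)(=O)Oc1c(C(=O)NCc2ccc(F)cc2)nc(Br)c2cccnc12`; in a functional assay on MCF7 cells (Homo sapiens) for cytotoxicity, read by MTT assay, with a stated time of 72 h (a higher number here means a weaker inhibitor, a lower number a stronger inhibitor), compound 1 gives "not determined" (no result reported). Compound 2, `CC(C)(C)OC(=O)N1CCN(c2c(C(=O)NCc3ccc(F)cc3)nc(Br)c3cccnc23)CC1`; in this assay compound 2 gives > 10000 nM, which is a limit of the assay and not a number.

Going by the values given here, compound 1 therefore stands nowhere on the numbers: no single value is known for it, and the only other value shown is the limit of > 10000 nM in this assay, at which 1 of the 2 values shown sits. Compound 3, `NCCNc1c(C(=O)NCc2ccc(F)cc2)nc(Br)c2cccnc12`, differs from compound 1 by (2-aminoethyl)amino in place of (methylsulfonyl)oxy on an aromatic carbon. Among the compounds with values here, with no measured pair to compare, the size and direction of the step in this assay cannot be read from the data. Compound 3 is expected near 12000 nM, between 2000 nM and 60000 nM, with a real chance that only a limit is reported.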

Compound 3, half-maximal inhibitory concentration: 6000 nM
Compound 3: the middle estimate sits 2.0-fold (0.30 log units) above what was measured; measured number inside the range.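

Going by these compounds alone, compound 1 has no number in this assay, so no step to compound 3 can be read. The compounds shown leave open how far, and in which direction, (2-aminoethyl)amino in place of (methylsulfonyl)oxy shifts the result in this assay.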